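Ether-linked selenocyanate chain in place of an amide arm

The source may hold more compounds than are shown below. What is called first, only, known or untested is meant among the compounds shown, and "the series" means these compounds.

Compound 1 `COc1ccc(N(C)c2nc(C)nc3ccccc23)cc1C(=O)NCC[Se]C#N` belongs to a small set of selenocyanate-bearing compounds tested in a functional assay on A549 cells (Homo sapiens) for inhibition, read by MTT assay, with a stated time of 48 h; a lower number here means a stronger inhibitor, a higher number a weaker inhibitor. Compound 1 gives 187 nM, the second highest of the three numbers; compound 2 `Cc1nc(N(C)c2ccc([Se]C#N)c(F)c2)c2ccccc2n1` gives 4 nM, and compound 3 `COc1ccc(N(C)c2nc(C)nc3ccccc23)cc1C(=O)OCCCCCC[Se]C#N` gives 488 nM. Compound 4 `COc1ccc(N(C)c2nc(C)nc3ccccc23)cc1OCCCCC[Se]C#N` differs from compound 1 by a group of 9 heavy atoms (6 carbon, 1 nitrogen, 1 oxygen, 1 selenium; no ring) in place of a group of 8 heavy atoms (4 carbon, 2 nitrogen, 1 oxygen, 1 selenium; no ring), on an aromatic carbon. For the measured compounds named here, the one comparable measured step replaced the arm on the carbonyl carbon with a longer chain and gave a 2.6-fold higher number from compound 1 to compound 3 (0.42 log units; beyond the scatter). A change of similar kind is therefore expected to shift the number modestly upward, at most slightly beyond the scatter. Compound 4 is estimated at 300 nM, with a range of 120 nM to 750 nM, corresponding to an expected step of a 1.6-fold higher number from compound 1 to compound 4 (0.21 log units; within the scatter).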

Compound 4, half-maximal inhibitory concentration: 2440 nM
For compound 4 the middle estimate is 8.1-fold (0.91 log units) below the measured one; measured number above the stated range.
By their numbers in this assay, from the lowest: compound 2; then compound 1; then compound 3; then compound 4.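

Replacing the amide-bearing arm with the ether-linked selenocyanate chain, on this aromatic carbon ortho to a methoxy group, gives a 13-fold higher number from compound 1 to compound 4 (1.12 log units; beyond the scatter) in this assay. That large step exceeds the modest one seen on the carbonyl carbon, a 2.6-fold higher number from compound 1 to compound 3 (0.42 log units; beyond the scatter), and shows that keeping the selenocyanate does not preserve the number when this arm changes. No measurement shown accounts for the size of this step.

As far as these compounds go, the link and the chain change together in compound 4, so their separate shares stay open. An amine link carrying the same chain, or an ether with a two-carbon chain, would pull them apart.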